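The source may hold more compounds than are shown below. What is called first, only, known or untested is meant among the compounds shown, and "the series" means these compounds.

In a functional assay on the whole organism for positive allosteric modulation, with Mus musculus as the target (on this read-out lower numbers stand for an effect already at smaller amounts and higher numbers for an effect only at larger amounts of compound), compound 1 `CCC(=O)N(c1ccc(Cl)cc1)C1CCCC1N(C)C` gives 3 mg/kg and compound 2 `CCC(=O)N(c1ccc(F)cc1)C1CCCC1N(C)C` gives 5 mg/kg. The step between them is a 1.7-fold higher number from compound 1 to compound 2 (0.22 log units; within the scatter), so these two cannot be told apart. Compound 3 `CCC(=O)N(c1ccc(F)c(Cl)c1)C1CCCC1N(C)C` gives 0.2 mg/kg. Compound 2 therefore stands with compound 1 at the upper end of these numbers, well above compound 3.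

Compound 4 `CCC(=O)N(c1ccc(C(=O)OC)cc1)C1CCCC1N(C)C` keeps the core of compound 2 but carries methoxycarbonyl in place of fluoro on an aromatic carbon, para to a large group: methoxycarbonyl in place of fluoro on an aromatic carbon. Within the data shown here, two measured steps bear on this change. Fluoro in place of chloro was a small change, at a 1.7-fold higher number from compound 1 to compound 2 (0.22 log units; within the scatter). Chloro in place of hydrogen was a large one, at a 25-fold lower number from compound 2 to compound 3 (1.40 log units; beyond the scatter), so one small change on the aromatic ring can matter greatly here. Among the measured compounds shown here, no measured compound carries a group like methoxycarbonyl, so the direction is uncertain. The expected change is a modest move towards a higher number, estimated as a 2.4-fold higher number from compound 2 to compound 4 (0.38 log units; beyond the scatter). For compound 4 the estimated value is 12 mg/kg, with an expected range from 2 mg/kg to 60 mg/kg.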

Compound 4, dose for half-maximal effect: > 50 mg/kg
Compound 4 gave a limit, no number; the forecaster's own chance of this, stated with the estimate: 5%; at least 4.1-fold (0.61 log units) between middle value and limit.
By their numbers in this assay, from the lowest: compound 3; then compounds 1 and 2 (each within the scatter of the next). At a limit, above all of these: compound 4.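

In this assay compound 4 gives only a limit, not a number: the limit of > 50 mg/kg in this assay, at which 1 of the 4 values shown sits.

Methoxycarbonyl on this aromatic carbon, para to a large group, gives an at least 10-fold higher number from compound 2 to compound 4 (1.00 log units; beyond the scatter) when it replaces fluoro and an at least 16-fold higher number from compound 1 to compound 4 (1.22 log units; beyond the scatter) when it replaces chloro. Fluoro and chloro could not be told apart here, so the earlier compounds did not show whether this position is sensitive to the group it carries; methoxycarbonyl shows that a change here can cost much of the effect, by an amount the limit leaves unknown.

The change brings more heavy atoms and two hydrogen-bond acceptors at once, and the compounds shown cannot separate these. Also open, going by these compounds, is how a methyl, a methoxy or a nitrile group would behave at this position, and whether the added chloro of compound 3 would restore the effect alongside methoxycarbonyl.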